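The source may report more compounds than this note shows. Statements on the series, on what has been measured and on what is new or still open speak of the compounds shown alone.

Compound 1 `Cc1ccccc1-c1nc(CN2CCC(C(=O)NCCCN3CCC(C)(C)CC3)CC2)c(C)o1` was tested in an ADME assay on Huh7.5.1 cells (Homo sapiens) for cytotoxicity, read by ATP content, with a stated time of 48 h; on this read-out higher numbers stand for lower toxicity in this test and lower numbers for higher toxicity in this test; compound 1 gives 10200 nM.
Compound 2 `Cc1oc(-c2ccc(F)cc2)nc1CN1CCC(C(=O)NCCCN2C[C@H](C)C[C@H](C)C2)CC1` was also tested; in this assay compound 2 gives 12800 nM.
Compound 3 `Cc1ccccc1-c1nc(CN2CCC(C(=O)N3CCN(C4CCN(C)CC4)CC3)CC2)c(C)o1` was tested as well; in this assay compound 3 gives 19900 nM.

Among these three numbers, compound 2 has the second highest. Its nearest neighbour is compound 1, whose number is slightly lower, and the furthest is compound 3, whose number is somewhat higher; both of those gaps are within the usual scatter of repeated measurements, so the three compounds cannot be told apart on this read-out.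

The step of interest goes from compound 2 to compound 4 `Cc1ccc(-c2nc(CN3CCC(C(=O)NCCCN4C[C@H](C)C[C@H](C)C4)CC3)c(C)o2)c(C)c1`. The structural change is 2,4-dimethylphenyl in place of 4-fluorophenyl on an aromatic carbon. For the measured compounds named here, no measured pair of compounds shows this exact change, so nothing is known directly about its effect here.

Since the three measured compounds, which differ in their aromatic substituents, all sit within the scatter of one another, the step from compound 2 to compound 4 is expected to be small, with no clear direction beyond the scatter: a 1.1-fold lower number from compound 2 to compound 4 (0.05 log units; within the scatter). Compound 4 is therefore estimated at 11500 nM in this assay, within a range from 5500 nM to 24000 nM.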

Compound 4, half-maximal cytotoxic concentration: 4110 nM
Beside the measured number, compound 4's estimate is 2.8-fold (0.45 log units) above it; measured number below the stated range.
By their numbers in this assay, from the lowest: compound 4; then compounds 1, 2 and 3 (each within the scatter of the next).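

The aromatic group on this carbon of the five-membered ring is not a neutral site in this assay: 2,4-dimethylphenyl in place of 4-fluorophenyl gives a 3.1-fold lower number from compound 2 to compound 4 (0.49 log units; beyond the scatter), a modest step towards higher toxicity in this test. For the compounds shown here, this is the first comparison here between compounds that differ in one place, and it opens the first gap beyond the scatter, so the similar numbers of the earlier compounds did not mean that this group could be swapped freely. Nothing available explains the step, and the loss of fluorine cannot be separated from the gain of the two methyl groups.

Still open, as far as these compounds go, is how 4-methylphenyl or unsubstituted phenyl would read at this position, which could show how much of the step each methyl group carries. Compounds 1 and 3 also differ in the amine part, so they cannot show whether the step holds with other amine parts.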